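The source may report more compounds than this note shows. Statements on the series, on what has been measured and on what is new or still open speak of the compounds shown alone.

The measured compounds and their values in this study are:

Compound 1, `COC(=O)C1=C(C)NC(=O)NC1c1cccs1`: 19%
Compound 2, `CC1=C(C(=O)OC(C)(C)C)C(c2ccsc2)NC(=O)N1`: 47%
Compound 3, `CCCOC(=O)C1=C(C)N(C)C(=O)NC1c1ccco1`: 23%

All three were tested in an assay on membranes from HEK293 cells for displacement of a labelled ligand from adenosine receptor A2b (Homo sapiens), read by scintillation counting, with a stated time of 30 min, tested at 1 uM; a lower number here means less inhibition, a higher number more inhibition at the concentration tested (going by the name of the read-out). Compound 3 stands second highest of the three numbers. Its nearest neighbour is compound 1, whose value sits a few points lower, a gap that lies within the scatter of the measurement, so the two cannot be placed in any order. Compound 2 stands furthest from compound 3, its number being higher by a gap that lies beyond the scatter.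

The step under consideration leads from compound 3 to compound 4, `CC1=C(C(=O)OC(C)(C)C)C(c2ccco2)NC(=O)N1C`, which has not yet been measured in this assay. The change is tert-butyl in place of propyl on an oxygen next to a carbonyl group. Going by the values given here, no step between two measured compounds differing in one place alone is available, so the effect of this change cannot be read off directly. Compound 2, which carries tert-butyl on an oxygen next to a carbonyl group, gives the highest of the measured numbers, but it also differs from the others in further places, so only a loose hint can be drawn.

The step of a number 8 percentage points higher from compound 3 to compound 4 (within the scatter) is expected to be a modest rise, not certain to exceed the scatter. Compound 4 is estimated at 31%, within a range from 15% to 50%.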

Compound 4, a percentage reported as inhibition, at one concentration (the size of the read-out at that concentration, not a potency): 26%
Compound 4: middle estimate off by 5 percentage points, on the high side; low and high end bracket the measured number.
By their numbers in this assay, from the lowest: compounds 1, 3 and 4 (each within the scatter of the next); then compound 2.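

In this assay, tert-butyl in place of propyl on an oxygen next to a carbonyl group gives a number 3 percentage points higher from compound 3 to compound 4 (within the scatter), and this is the first direct reading of this change among the compounds shown. With the rest of the structure held fixed, the exchange of these two groups leaves the number indistinguishable from its starting level, so this position accepts tert-butyl as readily as propyl at the concentration tested. Nothing available bears on why the number stays where it does.

Still open, going by these compounds, is whether a group of another kind on this oxygen, such as benzyl, a longer chain such as hexyl, or a chain ending in an amine, would move the number beyond the scatter, and whether a free carboxylic acid in place of the ester would do so. On these data alone, the change has also been read on a single pair only, so whether it gives an equally small step on the other compounds, with their different substituents on the shared core, remains unknown.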